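Urea aryl variation on a shared quinazoline-type series

The source may report more compounds than this note shows. Statements on the series, on what has been measured and on what is new or still open speak of the compounds shown alone.

Measured so far in a functional assay on HepG2 cells (Homo sapiens) for antiproliferative activity, read by MTT assay; on this read-out lower numbers stand for stronger inhibition and higher numbers for weaker inhibition:
compound 1 `COc1ccccc1NC(=O)Nc1cccc(CNc2ncnc3cc(OC)c(OC)cc23)c1`: 27200 nM
compound 2 `COc1cc2ncnc(NCc3cccc(NC(=O)Nc4ccc(C(C)(C)C)cc4)c3)c2cc1OC`: 6850 nM

Compound 2 stands lowest of the two numbers in this assay; its nearest neighbour is compound 1, which differs from it only by the aryl group on the urea nitrogen, and the step of a 4.0-fold lower number from compound 1 to compound 2 (0.60 log units; beyond the scatter) is modest but beyond the scatter. Compound 3 `COc1cc2ncnc(NCc3cccc(NC(=O)Nc4ccccc4F)c3)c2cc1OC` is not yet measured. It differs from compound 2 by 2-fluorophenyl in place of 4-(tert-butyl)phenyl on an amide-type nitrogen. Going by the values given here, the only step that bears on this is the one from compound 1 to compound 2, where a 2-methoxyphenyl gave way to the same 4-(tert-butyl)phenyl that now leaves; compound 3 returns to a phenyl bearing a single substituent in the 2-position, though a fluorine rather than a methoxy. No direct comparison of 2-fluorophenyl exists in the set. Part of that step is therefore expected to reverse, so compound 3 is expected to give a higher number than compound 2, by roughly a 2.6-fold higher number from compound 2 to compound 3 (0.42 log units; beyond the scatter), landing between compound 2 and compound 1. The estimate for compound 3 in this assay is 18000 nM, with a range from 6000 nM to 50000 nM.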

Compound 3, half-maximal inhibitory concentration: 24900 nM
Beside the measured number, compound 3's estimate is 1.4-fold (0.14 log units) below it; low and high end bracket the measured number.
By their numbers in this assay, from the lowest: compound 2; then compounds 3 and 1 (each within the scatter of the next).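

In this assay, removing 4-(tert-butyl)phenyl gives a 3.6-fold higher number from compound 2 to compound 3 (0.56 log units; beyond the scatter), a modest change that is beyond the scatter. Fluoro in place of methoxy on the aromatic carbon gives a 1.1-fold lower number from compound 1 to compound 3 (0.04 log units; within the scatter), so 2-fluorophenyl and 2-methoxyphenyl cannot be told apart on this nitrogen, and among the three aryl groups only 4-(tert-butyl)phenyl stands apart. No measured evidence accounts for these differences.

Going by these compounds, whether the separation of compound 2 belongs to the tert-butyl group itself or to where it sits remains open, and a plain phenyl or a cyclohexyl on the same nitrogen would help to separate these readings. On these data alone, all three compounds share one core, so how these urea steps would carry over to a changed core also stays open.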